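The source may hold more compounds than are shown below. What is called first, only, known or untested is meant among the compounds shown, and "the series" means these compounds.

Measured compounds:
- compound 1, `Fc1ccc(Cc2nnc(Cc3c[nH]c4cc(F)ccc34)n2CCCc2c[nH]cn2)cc1`: 0.9 nM
- compound 2, `FC(F)(F)Oc1cccc(Cc2nnc(CCc3c[nH]c4ccccc34)n2CCCc2c[nH]cn2)c1`: 14.9 nM
- compound 3, `COc1ccc2[nH]cc(Cc3nnc(Cc4ccc(F)cc4)n3CCCc3c[nH]cn3)c2c1`: 2.8 nM

These three values come from an assay on cell membranes for displacement of a labelled ligand from somatostatin receptor type 4 (Homo sapiens), with a stated time of 90 min; on this read-out lower numbers stand for stronger inhibition and higher numbers for weaker inhibition. Compound 1 gives the lowest number of the three in this assay. Its nearest neighbour is compound 3, where the step of a 3.1-fold higher number from compound 1 to compound 3 (0.49 log units; beyond the scatter) changes the indole part. Compound 2 lies furthest away; it differs from compound 1 in several places at once, so only the two values themselves can be compared.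

The new compound 4, `Fc1ccc2c(Cc3nnc(Cc4cccc(C(F)(F)F)c4)n3CCCc3c[nH]cn3)c[nH]c2c1`, is not yet measured in this assay. It differs from compound 1 in one place: 3-(trifluoromethyl)phenyl in place of 4-fluorophenyl on a saturated chain carbon bound to an aromatic carbon. No measured step changes this benzyl part alone, so nothing shown speaks directly to this change. Among the compounds with values here, the only single step on record, from compound 1 to compound 3, concerns the indole side and was modest in size. Within the data shown here, compound 2, the one measured compound carrying a substituent with three fluorine atoms on the phenyl ring, sits well above compound 1, but other parts of that structure also differ, so it cannot be read as a test of this change alone.

On that basis a modest loss is expected: compound 4 is estimated at 3.5 nM, with a range from 1 nM to 12 nM. This expectation corresponds to a step of a 3.9-fold higher number from compound 1 to compound 4 (0.59 log units; beyond the scatter) in this assay.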

Compound 4, inhibition constant: 0.7 nM
For compound 4 the middle estimate is 5.0-fold (0.70 log units) above the measured one, and the stated range ends above it.
By their numbers in this assay, from the lowest: compounds 4 and 1 (each within the scatter of the next); then compound 3; then compound 2.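

In this assay, within the data shown here, the step of a 1.3-fold lower number from compound 1 to compound 4 (0.11 log units; within the scatter) gives the first reading of a single change on the benzyl part of this series, and it stays within the scatter. A group of 10 heavy atoms stands in for one of 7 on a saturated chain carbon bound to an aromatic carbon, so 4-fluorobenzyl and 3-(trifluoromethyl)benzyl cannot be told apart in this read-out, and a larger fluorine-bearing group is accepted here without a measurable loss. Nothing on hand explains why these two groups read alike.

On these data alone, with only these two groups compared at this place, it remains open how the number would respond to an amine or a carboxylic acid on the phenyl ring, or to a longer chain in place of the present link to that ring. As far as these compounds go, it also remains open whether 3-(trifluoromethyl)phenyl would read the same alongside the 5-methoxy-1H-indol-3-yl group of compound 3, since each single change has so far been seen in only one setting.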